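Aryl replacement on the shared core: compound 1 to compound 3

The source may report more compounds than this note shows. Statements on the series, on what has been measured and on what is new or still open speak of the compounds shown alone.

Among the measured compounds shown here, compound 1 `COC(=O)C1=C(C)N=C(C)/C(=C(\O)OC)C1c1ccccc1N` carries the lower of the two numbers so far in a functional assay (muscle tissue) with Cavia porcellus as the target (on this read-out lower numbers stand for an effect already at smaller amounts and higher numbers for an effect only at larger amounts of compound), where compound 1 gives 39800 nM. For the measured compounds named here, compound 2 `COC(=O)C1=C(C)N=C(C)/C(=C(\O)OC)C1c1cc(OC)c(OC)cc1OC` is the only other measured compound; in this assay compound 2 gives 1000000 nM, a gap beyond the scatter. The next compound in the series, compound 3 `COC(=O)C1=C(C)N=C(C)/C(=C(\O)OC)C1c1ccc(C#N)cc1`, differs from compound 1 in one place: 4-cyanophenyl in place of 2-aminophenyl on a saturated ring carbon. Going by the values given here, no step between two measured compounds matches this change, so the direction cannot be read from the series. The lone change at this position, from compound 1 to compound 2, weakened the read-out, and a move away from compound 1 is expected to weaken it here as well, as a modest step of a 2.0-fold higher number from compound 1 to compound 3 (0.30 log units; within the scatter). The expected value for compound 3 in this assay is 80000 nM, with a range from 15000 nM to 400000 nM.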

Compound 3, half-maximal effective concentration: 3470 nM
For compound 3 the middle estimate is 23-fold (1.36 log units) above the measured one; the whole stated range lies above it.
By their numbers in this assay, from the lowest: compound 3; then compound 1; then compound 2.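

In this assay, the aryl group on the saturated ring carbon can also shift the read-out toward lower numbers: 4-cyanophenyl in place of 2-aminophenyl gives an 11-fold lower number from compound 1 to compound 3 (1.06 log units; beyond the scatter). Among the compounds shown here, the only earlier change at this position went to a higher number, so compound 1 no longer marks the low end, and compound 3 now has the lowest of the three numbers at 3470 nM. No available evidence accounts for this step.

The compounds shown do not separate the effect of swapping the amine for the nitrile from that of the different location of each group on the phenyl ring. Going by these compounds, how a plain phenyl, or a phenyl bearing a chlorine or a nitro group, would read on this core also remains open.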